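The compounds below may be only part of what the source reports. "The series", "measured", "known", "first", "only" and "open" are said of these compounds alone.

Of the compounds shown here, two have been measured so far, compound 1 (`COc1ccc(NC(=O)Nc2ccc(C(=O)NO)cc2)cc1`) and compound 2 (`O=C(/C=C/c1ccc(NC(=O)Nc2ccccc2)cc1)NO`). In a functional assay on NAMALVA cells (Homo sapiens) for cytotoxicity, read by MTT assay, with a stated time of 72 h (a higher number here means a weaker inhibitor, a lower number a stronger inhibitor), compound 1 gives 4790 nM, while compound 2 gives 300 nM. Compound 2 therefore holds the lower of the two numbers, which makes it the stronger inhibitor of the pair, and the gap lies beyond the scatter of repeated measurements.

The next compound, compound 3 (`COc1ccc(NC(=O)Nc2ccc(/C=C/C(=O)NO)cc2)cc1`), is compound 2 with one small edit: methoxy in place of hydrogen on an aromatic carbon. Put simply, methoxy takes the place of hydrogen on an aromatic carbon, para to a large group, so that phenyl becomes 4-methoxyphenyl. Among the compounds with values here, no measured pair here isolates this change, so the data give no direct guide to its size or direction. The natural starting point is compound 2 itself, at 300 nM, and no change beyond the scatter is expected in this assay. The estimated step is small, a 1.2-fold higher number from compound 2 to compound 3 (0.07 log units; within the scatter). Compound 3 is estimated at 350 nM, with an expected range from 130 nM to 900 nM.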

Compound 3, half-maximal inhibitory concentration: 460 nM
The estimate for compound 3 lay 1.3-fold (0.12 log units) below the measured number; the range from low to high includes it.
By their numbers in this assay, from the lowest: compounds 2 and 3 (each within the scatter of the next); then compound 1.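

Placing methoxy on the aromatic carbon para to a large group, which turns phenyl into 4-methoxyphenyl, gives a 1.5-fold higher number from compound 2 to compound 3 (0.19 log units; within the scatter) in this assay, so this position accepts the added oxygen and carbon with no change that can be told from the scatter. Within the data shown here, compound 3 also offers the first pair in which the group bearing the hydroxycarbamoyl function differs alone, since 2-(hydroxycarbamoyl)ethenyl in place of hydroxycarbamoyl gives a 10-fold lower number from compound 1 to compound 3 (1.02 log units; beyond the scatter), a large step that shows this part of the molecule matters far more here than the methoxy swap does. Nothing available explains either the large step or the small one.

On these data alone, only hydrogen and methoxy have been compared at the position para to the large group, so the effect of a chlorine atom, an amine or a carboxylic acid there remains unknown. As far as these compounds go, it is equally open whether a longer chain carrying the hydroxycarbamoyl group would extend the gain seen with 2-(hydroxycarbamoyl)ethenyl, or whether that gain would also appear with the unsubstituted phenyl.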